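Cytotoxicity on HEL cells: indolyl to pyrrolidinyl swap

A few compounds are considered here, and "the series" means these few. Any claim that something is new, unique, unknown or untested is made for them only; others in the source may bear on it.

Two compounds of the series carry a thioether-linked arylalkyl chain on the shared core. Compound 1 `C=Cc1ccc(-c2cc(C)c3ncc(CSCc4ccccc4)n3c2)cc1` and compound 2 `Cc1cc(-c2ccc3[nH]ccc3c2)cn2c(CSCCc3ccccc3)cnc12` have both been tested in an ADME assay on HEL cells (Homo sapiens) for cytotoxicity, with a stated time of 3 days; on this read-out lower numbers stand for higher toxicity in this test and higher numbers for lower toxicity in this test. For compound 1 the reading in this assay is a limit of the assay, >= 100 ug/mL. For compound 2 the reading in this assay is likewise a limit and not a number, >= 20 ug/mL. Going by the values given here, compound 2 therefore stands only at a limit on this read-out, with no measured step between compound 1 and compound 2, since both values shown are limits, the limit of >= 100 ug/mL in this assay, at which 1 of the 2 values shown sits, and (the limit of >= 20 ug/mL in this assay, at which 1 of the 2 values shown sits).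

Compound 3 `Cc1cc(N2CCCC2)cn2c(CSCCc3ccccc3)cnc12` has not yet been measured in this assay. It differs from compound 2 by pyrrolidin-1-yl in place of 1H-indol-5-yl on an aromatic carbon. Among the compounds with values here, no measured step exists to anchor this change, so the expectation rests on the limit for compound 2 only. The step from compound 2 to compound 3 is expected to be small and toward no greater toxicity, a step that the limit leaves unreadable from compound 2 to compound 3. Compound 3 is estimated at 40 ug/mL in this assay, with a range from 20 ug/mL to 100 ug/mL, and the reading may again be a limit.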

Compound 3, minimum cytotoxic concentration: 20 ug/mL
Compound 3: the middle estimate sits 2.0-fold (0.30 log units) above what was measured; low and high end bracket the measured number.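

In this assay compound 3 gives the only true number among the compounds shown, 20 ug/mL, so this position now has a reading that is not a limit. Placing pyrrolidin-1-yl on this aromatic carbon instead of 1H-indol-5-yl, which removes the fused aromatic system and the hydrogen-bond donor, gives a number no higher from compound 2 to compound 3 (the limit leaves the size open). The size of this change cannot be read, because compound 2 stands at a limit and not at a number: the limit of >= 20 ug/mL in this assay, at which 1 of the 3 values shown sits.

On these data alone, whether the change raises toxicity at all or leaves it unchanged remains open, as does how much of the reading for compound 3 is specific to pyrrolidin-1-yl, and compound 1 differs from compound 3 in more than one place, so it cannot settle either question. A morpholin-4-yl group or an open-chain dimethylamino group on the same aromatic carbon would show whether the reading follows the five-membered ring or an amine at this place more generally.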